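Vero Cell Cytotoxicity Before and After a Nitrophenyl Swap

This account rests on a few compounds, and the source may have more. Where it says the series, first, only, none or still open, it means among the compounds named here.

Compound 1 `O=C(c1ccncc1)N1N=C(c2cc3ccccc3o2)CC1c1cccc([N+](=O)[O-])c1`: > 240000 nM
Compound 2 `CCn1cc(C(=O)N2N=C(c3cc4ccccc4o3)CC2c2ccc(OC)cc2O)c(=O)c2ccc(C)nc21`: > 154000 nM

In an ADME assay on Vero cells (Chlorocebus sabaeus) for cytotoxicity, read by MTT assay, with a stated time of 72 h (on this read-out higher numbers stand for weaker inhibition and lower numbers for stronger inhibition), compound 1 gives > 240000 nM, which is a limit of the assay and not a number. Compound 2 gives > 154000 nM in this assay, again a limit rather than a number. Among the compounds with values here, compound 2 therefore stands on no measured figure at all: its own result is the limit of > 154000 nM in this assay, at which 1 of the 2 values shown sits, and the only other value shown is the limit of > 240000 nM in this assay, at which 1 of the 2 values shown sits. Within the data shown here, nothing in these two results separates the compounds, and no step between them can be drawn.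

Compound 3 `CCn1cc(C(=O)N2N=C(c3cc4ccccc4o3)CC2c2ccccc2[N+](=O)[O-])c(=O)c2ccc(C)nc21` carries 2-nitrophenyl in place of 2-hydroxy-4-methoxyphenyl on a saturated ring carbon, that is, 2-nitrophenyl in place of 2-hydroxy-4-methoxyphenyl on a saturated ring carbon. Among the measured compounds shown here, with no measured step to lean on, and both known results sitting at limits, the expectation for this change in this assay is no shift beyond the scatter, with a limit the most likely outcome once more. Compound 3 is estimated at 200000 nM, between 100000 nM and 400000 nM, which corresponds to an expected step that the limit leaves unreadable from compound 2 to compound 3.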

Compound 3, half-maximal inhibitory concentration: > 85400 nM
Compound 3 was reported as a limit; the forecaster's own chance of this, stated with the estimate: 80%; the middle value lies beyond the limit too.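

In this assay compound 3 gives > 85400 nM, a limit of the assay and not a number. Compound 2 gives > 154000 nM, also a limit. Within the data shown here, no step from compound 2 to compound 3 can be read from these two limits. On these data alone, whether 2-nitrophenyl in place of 2-hydroxy-4-methoxyphenyl on a saturated ring carbon shifts the result at all stays open.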